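This account rests on a few compounds, and the source may have more. Where it says the series, first, only, none or still open, it means among the compounds named here.

Working notes on the series. For the measured compounds named here, in an ADME assay on microsomes from liver (Rattus norvegicus) for metabolic stability, read by LC-MS, tested at 1 uM (a higher number here means that more of the compound is left, a lower number that less of the compound is left), compound 1 `CS(=O)(=O)NC(=O)CCc1cn(-c2ccc(Br)cc2)nc1-c1ccc(Cl)cc1` gives 74%, the only true number so far. Compound 2 `CS(=O)(=O)NC(=O)CCc1cn(-c2ccc(Cl)cc2)nc1-c1ccc(Cl)cc1` reads > 99%, which is a limit of the assay and not a number. Going by the values given here, the single measured step is a number at least 25 percentage points higher from compound 1 to compound 2 (beyond the scatter), with chloro in place of bromo on an aromatic carbon.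

Compound 3 `CS(=O)(=O)NC(=O)CCc1cn(-c2ccc(Br)cc2)nc1-c1ccncc1` is not yet measured. It keeps the 4-bromophenyl group of compound 1 and changes the other aryl group: pyridin-4-yl in place of 4-chlorophenyl on an aromatic carbon. This puts pyridin-4-yl in place of 4-chlorophenyl on an aromatic carbon, next to the ring nitrogen.

The measured step bears on this only indirectly, since it was made at the 4-bromophenyl group and leaves the 4-chlorophenyl untouched. It shows that this assay can respond strongly to a small change in this series, but it gives no direction for the new one. Among the compounds with values here, with no measured step at this place, no shift beyond the scatter is expected, only a slight upward lean. The estimated step is a number 6 percentage points higher from compound 1 to compound 3 (within the scatter). The expected value for compound 3 is 80%, with an estimated range from 55% to 97%.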

Compound 3, percent of the compound remaining: 94%
The estimate for compound 3 lay 14 percentage points below the measured number; low and high end bracket the measured number.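

For the compounds shown here, until now the only step lay at the 4-bromophenyl group, so nothing was known about the other aryl position, on the aromatic carbon next to the ring nitrogen. This position also responds, beyond the scatter, to pyridin-4-yl in place of 4-chlorophenyl: a number 20 percentage points higher from compound 1 to compound 3 (beyond the scatter). The 4-bromophenyl group therefore does not by itself hold the read-out of this assay down, since compound 3 keeps that group and gives 94%.

Compound 2 reads > 99%, which is a limit of the assay and not a number, so the true size of the step to it stays open, and no pairing of pyridin-4-yl with the 4-chlorophenyl group on the other side can be judged from it: the limit of > 99% in this assay, at which 1 of the 3 values shown sits.

The compounds shown also leave open whether the ring nitrogen of pyridin-4-yl matters in that exact place or any replacement of 4-chlorophenyl would do the same, which pyridin-3-yl, unsubstituted phenyl or a 4-aminophenyl group at this position would begin to separate.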